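A few compounds are considered here, and "the series" means these few. Any claim that something is new, unique, unknown or untested is made for them only; others in the source may bear on it.

Measured so far in a functional assay on HT-29 cells (Homo sapiens) for inhibition, read by luminescence and CellTiter-Glo, with a stated time of 24 h (on this read-out higher numbers stand for an effect only at larger amounts of compound and lower numbers for an effect already at smaller amounts), are two compounds, which share one core.

compound 1 `CN1C(=S)[C@@H](NC(=O)c2nc(Cc3ccccc3)n(C3CCCCC3)n2)COc2ccccc21` gives 4000 nM
compound 2 `CN1C(=S)[C@@H](NC(=O)c2nc(Cc3ccccc3)n(CC3CCOC3)n2)COc2ccccc21` gives 4420 nM

For the measured compounds named here, neither measured compound stands apart, as the only step is a 1.1-fold higher number from compound 1 to compound 2 (0.04 log units; within the scatter) with (oxolan-3-yl)methyl in place of cyclohexyl on an aromatic nitrogen. Going by the values given here, compound 2 therefore sits level with the only other value.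

The next compound is compound 3 `CN1C(=S)[C@@H](NC(=O)c2nc(Cc3ccccc3)n(C3CCNC3)n2)COc2ccccc21`, and the change is pyrrolidin-3-yl in place of (oxolan-3-yl)methyl on an aromatic nitrogen at the same aromatic nitrogen. That single measured step bears on this change, since it concerns the same place. It shows one replacement there without a step beyond the scatter, but one step is thin evidence. Among the compounds with values here, the entering pyrrolidin-3-yl carries a hydrogen-bond donor, and no measured compound has one on this nitrogen, so the data do not show what such a group does here.

No step beyond the scatter is expected in this assay, though in either direction the uncertainty is wide. The estimated step is a 1.1-fold higher number from compound 2 to compound 3 (0.05 log units; within the scatter) as the working expectation. For compound 3 the estimate is 5000 nM with 1800 nM to 14000 nM as the expected range.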

Compound 3, half-maximal effective concentration: 1070 nM
Compound 3: the middle estimate sits 4.7-fold (0.67 log units) above what was measured; measured number outside the range, below it.
By their numbers in this assay, from the lowest: compound 3; then compounds 1 and 2 (each within the scatter of the next).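

In this assay, this aromatic nitrogen no longer looks indifferent to its substituent: pyrrolidin-3-yl gives a 4.1-fold lower number from compound 2 to compound 3 (0.62 log units; beyond the scatter) and a 3.7-fold lower number from compound 1 to compound 3 (0.57 log units; beyond the scatter), whereas the earlier exchange of cyclohexyl for (oxolan-3-yl)methyl gave only a 1.1-fold higher number from compound 1 to compound 2 (0.04 log units; within the scatter). Among the three compounds, the lower number goes with the only group here that carries a hydrogen-bond donor, though a single compound cannot separate that donor from the other features of pyrrolidin-3-yl. The size of the step is modest, and nothing available accounts for it.

The compounds shown leave open whether the ring nitrogen with its hydrogen is what matters, which a pyrrolidine bearing a methyl group on that nitrogen, or a cyclopentyl ring carrying a hydroxyl group, would test. They also leave open whether a ring is needed at all, which an open-chain amine such as 2-aminoethyl would address, and how a carboxylic acid at this nitrogen would read in this assay.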